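The compounds below may be only part of what the source reports. "The series", "measured", "known", "first", "only" and "open" are said of these compounds alone.

In a physicochemical assay for solubility, read by HPLC, in phosphate buffer, measured as kinetic solubility, with a stated time of 1 h, at pH 7.4, tested at 250 uM (on this read-out lower numbers stand for lower solubility and higher numbers for higher solubility), compound 1 (`CC(C)CN1CCC(c2ccc3c(c2)oc(=O)n3C(=O)NCCCCc2ccccc2)CC1`) gives < 1000 nM, which is a limit of the assay and not a number. Compound 2 (`CCCCCNC(=O)n1c(=O)oc2cc(-c3ccc(F)cc3)ccc21`) gives < 1000 nM, which is also a limit. Compound 3 (`CC(C)CNC(=O)n1c(=O)oc2cc(C3CCCCN3C)ccc21`) is the only one of the three with a true number, and in this assay compound 3 gives 190000 nM.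

Compound 4 (`CN1CCN(c2ccc3c(c2)oc(=O)n3C(=O)NCCCCc2ccccc2)CC1=O`) keeps the core and the side chain of compound 1. The change is 4-methyl-3-oxopiperazin-1-yl in place of 1-isobutylpiperidin-4-yl on an aromatic carbon.

Going by the values given here, no measured pair isolates this change, so the size of the step in this assay is a matter of judgement. A modest move towards higher numbers is expected, probably beyond the scatter, though a second reading at the limit remains quite possible. Compound 3 at 190000 nM shows how high the read-out can go, but it differs from compound 4 in more than one place and serves only as a loose point of comparison.

The expected change is an at least 5.0-fold higher number from compound 1 to compound 4 (0.69 log units; beyond the scatter), an estimate made against a limit and not against a number. For compound 4 the estimated value is 5000 nM, with an expected range of 1000 nM to 40000 nM.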

Compound 4, solubility: < 1000 nM
Compound 4: a limit, no number; the forecaster's own chance of this, stated with the estimate: 35%; at least 5.0-fold (0.69 log units) between middle value and limit.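

Compound 1 and compound 4 both read as limits and not as numbers, so no step can be read between them: the limit of < 1000 nM in this assay, at which 3 of the 4 values shown sit.

The compounds shown leave open where the two true solubilities lie, and so whether 4-methyl-3-oxopiperazin-1-yl in place of 1-isobutylpiperidin-4-yl on an aromatic carbon shifts the read-out at all.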